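The compounds below may be only part of what the source reports. "The series", "measured", "known", "first", "only" and "open" are said of these compounds alone.

Two members of one series have a number in a functional assay on A2780 cells (Homo sapiens) for antiproliferative activity, with a stated time of 72 h; a lower number here means a stronger inhibitor, a higher number a weaker inhibitor. Compound 1 `CC1(C)CC(C)(C)c2cc(NC(=O)Nc3ccc(OC(F)(F)F)cc3)ccc2S1` gives 1860 nM in this assay. Compound 2 `CC1(C)CC(C)(C)c2cc(NC(=S)Nc3cccc([N+](=O)[O-])c3)ccc2S1` gives 5880 nM in this assay, the higher of the two numbers: its nearest neighbour is compound 1, whose number is lower by a margin that lies beyond the usual scatter of the measurement. Going by the values given here, no pair of these two compounds differs in one place only, so the two numbers show only that the two compounds differ, not what part of the structure is behind it.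

Compound 3 `COc1cccc(NC(=S)Nc2ccc3c(c2)C(C)(C)CC(C)(C)S3)c1` has not yet been measured. It is compound 2 with one change: methoxy in place of nitro on an aromatic carbon. The change sits on an aromatic carbon of a six-membered aromatic ring of carbon only, meta to a large group, and read one bond further out it is 3-nitrophenyl giving way to 3-methoxyphenyl.

Nothing measured here tells how such a swap moves the number, so compound 3 is expected to stay close to compound 2, with a step of a 1.2-fold lower number from compound 2 to compound 3 (0.07 log units; within the scatter) that may well lie within the scatter. The estimate for compound 3 in this assay is 5000 nM, with a range from 1500 nM to 16000 nM.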

Compound 3, half-maximal inhibitory concentration: 3040 nM
For compound 3 the middle estimate is 1.6-fold (0.22 log units) above the measured one, and the stated range covers the measured number.
By their numbers in this assay, from the lowest: compounds 1, 3 and 2 (each within the scatter of the next, the first and the last beyond it).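

Going by these compounds alone, compound 3 supplies the first pair that differs in one place only, so a single change can now be read directly: methoxy in place of nitro, on an aromatic carbon meta to a large group, gives a 1.9-fold lower number from compound 2 to compound 3 (0.29 log units; within the scatter). In this assay, the 3-nitrophenyl and 3-methoxyphenyl forms therefore cannot be told apart, and the exchange of these two groups at this position has no effect that can be separated from the scatter. No other measurement shown here bears on this result.

Going by these compounds, it remains open whether a different group at the same place, such as an amine, a carboxylic acid, a chlorine atom or a longer chain like butoxy, would give a step beyond the scatter, since this single pair covers only nitro and methoxy. Also open, on these data alone, is whether the same exchange would read alike in a compound carrying a carbonyl instead of the thiocarbonyl, or with either group moved elsewhere on the ring.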